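From compound 1 to compound 3: cyclopropyl replaced by ethyl

The source may report more compounds than this note shows. Statements on the series, on what has been measured and on what is new or still open speak of the compounds shown alone.

For the measured compounds named here, compound 1 `c1ccc(OCC2=NCCN2)c(CC2CC2)c1` gives 1700 nM in an assay on isolated protein for agonist activity at Alpha-2B adrenergic receptor (Homo sapiens) (on this read-out higher numbers stand for an effect only at larger amounts of compound and lower numbers for an effect already at smaller amounts), the lowest of the two numbers measured so far; compound 2 `CCCc1ccccc1OC(C)C1=NCCN1` gives 5010 nM in this assay, a gap beyond the scatter. Compound 3 `CCCc1ccccc1OCC1=NCCN1` is not yet measured. It differs from compound 1 in one place: ethyl in place of cyclopropyl on a saturated chain carbon bound to an aromatic carbon, the same difference cut one bond further out reading cyclopropylmethyl to propyl. Going by the values given here, no measured pair shows this change, so its direction is open; a small step, likely none beyond the scatter, is expected. The expected step is a 1.3-fold higher number from compound 1 to compound 3 (0.11 log units; within the scatter). Compound 3 is estimated at 2200 nM, between 900 nM and 5500 nM.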

Compound 3, half-maximal effective concentration: 2510 nM
Compound 3: the middle estimate sits 1.1-fold (0.06 log units) below what was measured, and the stated range covers the measured number.
By their numbers in this assay, from the lowest: compounds 1, 3 and 2 (each within the scatter of the next, the first and the last beyond it).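

In this assay the step with ethyl in place of cyclopropyl on a saturated chain carbon bound to an aromatic carbon is a 1.5-fold higher number from compound 1 to compound 3 (0.17 log units; within the scatter) and stays within the scatter, so at this position the three-membered ring can be lost without a step beyond it. Hydrogen in place of methyl on the chain carbon bound to the oxygen gives a 2.0-fold lower number from compound 2 to compound 3 (0.30 log units; within the scatter) and also stays within the scatter. Nothing at hand accounts for either step. From the compounds shown here alone, whether a longer chain or an amine at the position of the propyl group would give a step beyond the scatter stays open.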